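This account rests on a few compounds, and the source may have more. Where it says the series, first, only, none or still open, it means among the compounds named here.

Measured so far:
- Compound 1 `O=C(CCCCCNC(=S)N/N=C(\c1ccccc1)c1ccccn1)NO`: 2030 nM
- Compound 2 `O=C(CCCCCNC(=S)N/N=C(\c1ccccc1)c1ccccc1[N+](=O)[O-])NO`: 1310 nM

Both values come from a functional assay on K562/A02 cells (Homo sapiens) for antiproliferative activity, read by MTT assay; on this read-out higher numbers stand for weaker inhibition and lower numbers for stronger inhibition. Compound 2 has only compound 1 for comparison, and the two cannot be separated: the measured step is a 1.5-fold lower number from compound 1 to compound 2 (0.19 log units; within the scatter).

The next compound is compound 3 `O=C(CCCCCNC(=S)N/N=C(\c1ccccc1)c1ccc([N+](=O)[O-])cc1)NO`, an isomer of compound 2: 4-nitrophenyl in place of 2-nitrophenyl on a carbon with a double bond to nitrogen. The nitro group stays on the ring and the rest of the structure is unchanged.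

Among the compounds with values here, only one measured step bears on this change, the step to compound 2 at the same carbon, a 1.5-fold lower number from compound 1 to compound 2 (0.19 log units; within the scatter). Within the data shown here, it is a different replacement, and no measured compound carries the 4-nitrophenyl, so the evidence is thin. No shift beyond the scatter is expected in this assay. The expected step is a 1.1-fold higher number from compound 2 to compound 3 (0.03 log units; within the scatter). For compound 3 the estimated value is 1400 nM, with an expected range of 600 nM to 3200 nM.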

Compound 3, half-maximal inhibitory concentration: 4530 nM
Beside the measured number, compound 3's estimate is 3.2-fold (0.51 log units) below it; measured number above the stated range.
By their numbers in this assay, from the lowest: compounds 2 and 1 (each within the scatter of the next); then compound 3.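

In this assay, the place of the nitro group on the ring at this carbon changes the result, even though the two groups have the same atoms: 4-nitrophenyl in place of 2-nitrophenyl gives (a 3.5-fold higher number from compound 2 to compound 3 (0.54 log units; beyond the scatter)). The replacement of pyridin-2-yl by 4-nitrophenyl also gives a step beyond the scatter (a 2.2-fold higher number from compound 1 to compound 3 (0.35 log units; beyond the scatter)), so this position responds to the group it carries, which the step from pyridin-2-yl to 2-nitrophenyl could not show. Nothing measured here accounts for the gap between the two isomers.

Going by these compounds, whether a phenyl ring carrying an amine or a carboxylic acid at this carbon would fall with compound 3 or with compound 2 remains open. Also open, on these data alone, is whether the gap between the isomers would persist with a longer chain in place of the one in the shared core.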